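Ethyl to Ethoxycarbonyl on a Ring Nitrogen: Cytotoxicity Outlook

This account rests on a few compounds, and the source may have more. Where it says the series, first, only, none or still open, it means among the compounds named here.

Of the compounds shown here, three have been measured in an ADME assay on HEK-293T cells (Homo sapiens) for cytotoxicity, read by MTT assay, with a stated time of 48 h; on this read-out higher numbers stand for lower toxicity in this test and lower numbers for higher toxicity in this test. Compound 1 `CCN1CCN(CC(=O)O[C@@H]2C[C@@H]3CC[C@@]2(C)C3(C)C)CC1` gives 130000 nM. Compound 2 `CCN1CCN(CCC(=O)O[C@@H]2C[C@@H]3CC[C@@]2(C)C3(C)C)CC1` gives 264000 nM. Compound 3 `CCOC(=O)N1CCN(CC(=O)O[C@@H]2C[C@@H]3CC[C@@]2(C)C3(C)C)CC1` gives 227000 nM. Compound 3 differs from compound 1 by ethoxycarbonyl in place of ethyl on an amine nitrogen in a ring, and this gave a 1.7-fold higher number from compound 1 to compound 3 (0.24 log units; within the scatter). How the core of compound 2 differs from the core of compound 1 is not broken down here; the two values stand within the scatter of each other.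

Compound 4 `CCOC(=O)N1CCN(CCC(=O)O[C@@H]2C[C@@H]3CC[C@@]2(C)C3(C)C)CC1` has not yet been measured in this assay. It differs from compound 2 by ethoxycarbonyl in place of ethyl on an amine nitrogen in a ring, the same change as before. Compound 4 is expected to give about 350000 nM, with a likely range from 180000 nM to 700000 nM, because the same change earlier gave a 1.7-fold higher number from compound 1 to compound 3 (0.24 log units; within the scatter). The estimated step is a 1.3-fold higher number from compound 2 to compound 4 (0.12 log units; within the scatter), again within the scatter.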

Compound 4, half-maximal cytotoxic concentration: 110000 nM
Beside the measured number, compound 4's estimate is 3.2-fold (0.50 log units) above it; the measured number lies below the stated range.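

On the core of compound 2, ethoxycarbonyl in place of ethyl on an amine nitrogen in a ring gave a 2.4-fold lower number from compound 2 to compound 4 (0.38 log units; beyond the scatter) in this assay. Set beside the earlier step, the same change does not carry over unchanged from one core to the other: the same change on two cores in this assay, a 1.7-fold higher number (0.24 log units; within the scatter) from compound 1 to compound 3 and a 2.4-fold lower number (0.38 log units; beyond the scatter) from compound 2 to compound 4, 4.2-fold (0.62 log units) apart, beyond the scatter of two such steps. Within the data shown here, with only one pair on each core, this shows that the outcome of the change depends on the core in these compounds, but it does not show why, and it gives no rule for other cores.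

The compounds shown leave open what this change does on a core with a longer chain leading to the ester. They also leave open whether acetyl or methoxycarbonyl on the same nitrogen would follow ethoxycarbonyl.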